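A few compounds are considered here, and "the series" means these few. Any claim that something is new, unique, unknown or untested is made for them only; others in the source may bear on it.

Measured in a functional assay on NCI-H460 cells (Homo sapiens) for antiproliferative activity, with a stated time of 72 h; on this read-out higher numbers stand for weaker inhibition and lower numbers for stronger inhibition
compound 1 `CCCC#Cc1cc([C@@H]2O[C@H](CO)[C@@H](O)[C@H]2O)n2ncnc(N)c12` gives 400 nM
compound 2 `CCCCC#Cc1cc([C@@H]2O[C@H](CO)[C@@H](O)[C@H]2O)n2ncnc(N)c12` gives 1700 nM
Not yet measured
compound 3 `Nc1ncnn2c([C@@H]3O[C@H](CO)[C@@H](O)[C@H]3O)cc(C#CC3CC3)c12`

In this assay compound 2 has the higher of the two numbers (1700 nM) and is the weaker of the pair. The change to compound 3 is cyclopropyl in place of butyl on a triple-bonded carbon. Among the measured compounds shown here, one measured step bears on it, made on the same chain: methyl in place of hydrogen on a saturated chain carbon (a 4.3-fold higher number from compound 1 to compound 2 (0.63 log units; beyond the scatter)). That step is modest but beyond the scatter. No ring on the triple-bonded carbon has been measured, so the transfer is uncertain. A modest move of similar size toward a lower number is expected (a 4.3-fold lower number from compound 2 to compound 3 (0.63 log units; beyond the scatter)). Compound 3 is estimated at 400 nM (expected range 120 nM to 1300 nM).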

Compound 3, half-maximal inhibitory concentration: 80 nM
Beside the measured number, compound 3's estimate is 5.0-fold (0.70 log units) above it, outside the stated range (below it).
By their numbers in this assay, from the lowest: compound 3; then compound 1; then compound 2.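

In this assay, this position on the triple-bonded carbon tolerates a ring, and the ring gives the lowest number of the three compounds: a 21-fold lower number from compound 2 to compound 3 (1.33 log units; beyond the scatter). Chain shortening alone does not account for this, since cyclopropyl also stands apart from the propyl chain, with a 5.0-fold lower number from compound 1 to compound 3 (0.70 log units; beyond the scatter). No data are available here to explain the difference between the ring and the open chains.

From the compounds shown here alone, whether the lower number is specific to cyclopropyl remains open, as cyclobutyl, cyclopentyl or phenyl on the triple-bonded carbon would be needed to tell. Going by these compounds, it is also open whether an ethyl or methyl chain would continue the trend seen from butyl to propyl, or whether the ring would still read lower than these shorter chains.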